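Alkynyl nucleoside series: chain shortening and Vero cytotoxicity

The compounds below may be only part of what the source reports. "The series", "measured", "known", "first", "only" and "open" are said of these compounds alone.

Measured compounds:
- compound 1, `CCCCCCCCCCCCC#Cc1cn(C2C=CC(O)C2)c(=O)[nH]c1=O`: > 100 ug/mL; > 100 ug/mL; 125 ug/mL (3 entries)
- compound 2, `CCCCCCCCCCC#Cc1cn(C2C=CC(O)C2)c(=O)[nH]c1=O`: > 125 ug/mL

Working notes. In an ADME assay on Vero cells (Chlorocebus sabaeus) for cytotoxicity, read by MTT assay, with a stated time of 72 h (a lower number here means that less compound is tolerated, a higher number that more compound is tolerated), compound 1 gives > 100 ug/mL; > 100 ug/mL; 125 ug/mL (3 entries), a set of several entries. In this assay compound 2 gives > 125 ug/mL, which is a limit of the assay and not a number. Going by the values given here, compound 2 therefore stands only at the ceiling of the range; no single number is known for it, and no step between compound 1 and compound 2 can be counted.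

Compound 3, `CCCCCCCCC#Cc1cn(C2C=CC(O)C2)c(=O)[nH]c1=O`, differs from compound 2 by hydrogen in place of ethyl on a saturated chain carbon, eight bonds along the chain from a triple-bonded carbon. The step in this assay is expected to be none beyond the scatter, or at most a small move toward more compound tolerated, because the limit of > 125 ug/mL in this assay, at which 1 of the 2 values shown sits, and the several entries of compound 1 in this assay, > 100 ug/mL; > 100 ug/mL; 125 ug/mL (3 entries) both sit at or near the ceiling of the assay, leaving little room for a counted shift. The step from compound 2 to compound 3 is thus estimated as a step that the limit leaves unreadable from compound 2 to compound 3. Compound 3 is expected at 150 ug/mL, with a range from 80 ug/mL to 300 ug/mL, and a limit rather than a number is the more likely report.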

Compound 3, half-maximal cytotoxic concentration: > 125 ug/mL
Compound 3 was reported as a limit; the forecaster's own chance of this, stated with the estimate: 75%; the middle value lies beyond the limit too.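

In this assay compound 3 gives > 125 ug/mL, a limit of the assay and not a number. Compound 2 gives > 125 ug/mL, likewise a limit. Going by these compounds alone, no step between compound 2 and compound 3 can be read. Left open is whether hydrogen in place of ethyl shifts the tolerated concentration at all; neither compound has a single number.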